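Swapping a benzyl for a bicyclic amine: toxicity outlook

The source may hold more compounds than are shown below. What is called first, only, known or untested is meant among the compounds shown, and "the series" means these compounds.

Measured compounds:
compound 1 `COc1ccc2[nH]c(C(=O)N3CC(=O)N(Cc4ccccc4)[C@@H](CCc4ccccc4)C3)cc2c1` with > 30000 nM
compound 2 `COc1cccc(CN2C(=O)CN(C(=O)c3cc4cc(OC)ccc4[nH]3)C[C@@H]2c2ccccc2)c1` with > 10000 nM

The shared core carries an indole amide on a six-membered ring. For compound 1 the read-out in an ADME assay on Vero cells (Chlorocebus sabaeus) for cytotoxicity, with a stated time of 7 days (on this read-out lower numbers stand for higher toxicity in this test and higher numbers for lower toxicity in this test), is a limit and not a number: it reached (the limit of > 30000 nM in this assay, at which 1 of the 2 values shown sits). For compound 2 the read-out in this assay is likewise a limit, (the limit of > 10000 nM in this assay, at which 1 of the 2 values shown sits). Among the compounds with values here, neither compound therefore shows a measurable half-maximal cytotoxic concentration within the range tested, and no step between them can be computed.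

Compound 3 `COc1ccc2[nH]c(C(=O)N3CC(=O)N(Cc4ccccc4)[C@@H](CN4CCn5cccc5C4)C3)cc2c1` is not yet measured. It differs from compound 1 by a group of 9 heavy atoms (7 carbon, 2 nitrogen; one five-membered aromatic ring with 1 hetero atom, one six-membered non-aromatic ring with 2 hetero atoms) in place of a group of 7 heavy atoms (7 carbon; one six-membered aromatic ring of carbon only), on a saturated chain carbon bound to a saturated ring carbon. The change sits on the side chain that hangs off the saturated ring carbon, while the indole amide and the benzyl on the ring nitrogen remain. With both measured compounds sitting at limits, no direction can be read from the data, and no step beyond the usual scatter is expected in this assay. Compound 3 is expected to reach 30000 nM, with a range from 10000 nM to 100000 nM, and the estimate implies a step of a number no higher from compound 1 to compound 3 (the limit leaves the size open).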

Compound 3, half-maximal cytotoxic concentration: > 100000 nM
Compound 3: a limit, no number; the forecaster's own chance of this, stated with the estimate: 70%; middle value at least 3.3-fold (0.52 log units) away from the limit.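

Within the data shown here, the read-outs of compound 1 and compound 3 are both limits and not numbers, and no step between the two can be read. The compounds shown leave open the actual half-maximal cytotoxic concentration of each, and whether replacing the benzyl with the group in compound 3 changes toxicity in this test at all.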